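Will a trifluoromethyl aryl group stay within the limit?

The compounds below may be only part of what the source reports. "The series", "measured", "known", "first", "only" and "open" are said of these compounds alone.

Measured so far in an ADME assay on MT2 cells (Homo sapiens) for cytotoxicity, read by XTT assay, with a stated time of 4 days; a higher number here means that more compound is tolerated, a lower number that less compound is tolerated:
Compound 1 `Cc1nc(C(NC(=O)C(=O)Nc2ccc(F)cc2)C2CCCCN2)sc1CO`: limit of > 113000 nM
Compound 2 `Cc1nc(C(NC(=O)C(=O)Nc2ccc(F)cc2F)C2CCCCN2)sc1CO`: limit of > 110000 nM
Compound 3 `Cc1nc(C(NC(=O)C(=O)NC2CCCCCC2)C2CCCCN2)sc1CO`: limit of > 90000 nM

Compound 3 stands only at a limit, > 90000 nM. The other two compounds also reached limits, so the three cannot be placed in any order.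

Compound 4 `Cc1nc(C(NC(=O)C(=O)Nc2ccc(C(F)(F)F)cc2)C2CCCCN2)sc1CO` keeps the shared core and changes one group: 4-(trifluoromethyl)phenyl in place of cycloheptyl on an amide-type nitrogen. In short, 4-(trifluoromethyl)phenyl replaces cycloheptyl on an amide-type nitrogen.

Among the compounds with values here, three measured steps bear on this change. Two swap the group at that same place, a step that the two limits leave unreadable from compound 1 to compound 3 and a step that the two limits leave unreadable from compound 2 to compound 3. The third, a step that the two limits leave unreadable from compound 1 to compound 2, adds a fluoro group to the aromatic ring. None of them has a readable size, so they give no direction to follow.

Compound 1 comes closest, with 4-fluorophenyl on that nitrogen, and its result is a limit, > 113000 nM. On that basis, compound 4 is expected to give a limit too. The estimated step that the limit leaves unreadable from compound 3 to compound 4 stays within the usual scatter, and no direction is expected in this assay.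

For compound 4 the estimated value is 95000 nM, with an expected range from 40000 nM to 125000 nM.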

Compound 4, half-maximal cytotoxic concentration: > 75500 nM
Compound 4 ended at the assay's limit; the forecaster's own chance of this, stated with the estimate: 75%; the middle value lies beyond the limit too.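

The results for compound 1, compound 2, compound 3 and compound 4 in this assay are all limits, so the steps from compound 4 to the other three cannot be read. The compounds shown leave open where each half-maximal cytotoxic concentration truly lies, and whether changing the group on the amide-type nitrogen shifts it at all.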